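Replacing methylsulfanyl with a larger selenium group in compound 3

The compounds below may be only part of what the source reports. "The series", "measured", "known", "first", "only" and "open" are said of these compounds alone.

Compound 1 `C[Se]/C(=N\C(=O)c1sccc1Cl)NC(=O)c1sccc1Cl`: 690 nM
Compound 2 `C[Se]/C(=N\C(=O)c1cnc2ccccc2c1)NC(=O)c1cnc2ccccc2c1`: 4160 nM
Compound 3 `CS/C(=N\C(=O)c1csc([N+](=O)[O-])c1)NC(=O)c1csc([N+](=O)[O-])c1`: 63400 nM

In a functional assay on HepG2 cells (Homo sapiens) for cytotoxicity, read by MTT assay, with a stated time of 72 h (a higher number here means a weaker inhibitor of growth, a lower number a stronger inhibitor of growth), compound 3 gives 63400 nM, the highest number of the three and the weakest inhibitor of growth in this set, since its gaps to compound 2 and to compound 1 both lie beyond the usual scatter. Compound 3 carries two nitro-substituted aryl groups around the shared core, whereas compound 1 and compound 2 carry other aryl groups together with a methylselanyl substituent; no pair of these compounds differs in one place only, so the data allow no clean attribution of the differences.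

Compound 4 `O=C(/N=C(/NC(=O)c1csc([N+](=O)[O-])c1)[Se]Cc1ccccc1)c1csc([N+](=O)[O-])c1` is not yet measured in this assay. It differs from compound 3 in one place: a group of 8 heavy atoms (7 carbon, 1 selenium; one six-membered aromatic ring of carbon only) in place of a group of 2 heavy atoms (1 carbon, 1 sulfur; no ring), on a carbon with a double bond to nitrogen. Among the compounds with values here, no measured pair isolates a change at this position, so the expectation for compound 4 rests only on the standing of compound 3, which gives 63400 nM, and on the general tendency of the other two compounds, with selenium in the same place, to give lower numbers. A moderate decrease is expected, a 3.2-fold lower number from compound 3 to compound 4 (0.50 log units; beyond the scatter), though a result within the scatter would not surprise. Compound 4 is therefore estimated at 20000 nM in this assay, with a range from 5000 nM to 80000 nM.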

Compound 4, concentration for 50% growth inhibition: 34100 nM
Compound 4: middle estimate off by 1.7-fold (0.23 log units), on the low side; the range from low to high includes it.
By their numbers in this assay, from the lowest: compound 1; then compound 2; then compounds 4 and 3 (each within the scatter of the next).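

In this assay, replacing methylsulfanyl with the group of 8 heavy atoms, which holds selenium and a six-membered aromatic ring of carbon only, gives a 1.9-fold lower number from compound 3 to compound 4 (0.27 log units; within the scatter), so the two compounds cannot be told apart in this assay. Within the data shown here, this is the first step in the set that isolates a change on this carbon with a double bond to nitrogen, and it shows that, with the nitro-substituted aryl groups kept, a much larger group can stand there without a shift beyond the usual scatter. The step swaps sulfur for selenium and adds the aromatic ring in a single change, and nothing measured here offers an explanation for the result.

The compounds shown leave open what each of those two parts contributes alone, which a methylselanyl group or a benzylsulfanyl group carried with these same nitro-substituted aryl groups would separate. They also leave open whether the position responds to a different kind of group, such as an amine or a longer alkyl chain, and whether the same change would give a similar step with the aryl groups of compound 1 or compound 2.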